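The source may hold more compounds than are shown below. What is called first, only, known or untested is meant among the compounds shown, and "the series" means these compounds.

Measured compounds in the series:

- compound 1, `N#CC1=C(N)Oc2c(c3nc4ccccc4nc3c3ccccc23)C12C(=O)N(Cc1cnnn1-c1ccc(N)cc1)c1ccccc12`, with 45200 nM
- compound 2, `N#CC1=C(N)Oc2c(N)cc3nc4ccccc4nc3c2C12C(=O)N(Cc1cnnn1-c1ccc(Cl)cc1)c1ccccc12`, with > 50000 nM

In a functional assay on HCT-116 cells (Homo sapiens) for antiproliferative activity, read by MTT assay, with a stated time of 48 h (on this read-out lower numbers stand for stronger inhibition and higher numbers for weaker inhibition), compound 1 gives 45200 nM, a weak result. Compound 2 reaches only a limit of the assay, > 50000 nM, so no number is known for it; this is the situation described by the limit of > 50000 nM in this assay, at which 1 of the 2 values shown sits. The two compounds differ in more than one place, so nothing can be said of any single change between them beyond what the two values themselves show: both sit at the weak end of what this assay can report.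

Compound 3, `Cc1cc(C)cc(-n2nncc2CN2C(=O)C3(C(C#N)=C(N)Oc4c(N)cc5nc6ccccc6nc5c43)c3ccccc32)c1`, has not yet been tested. It differs from compound 2 in one place: 3,5-dimethylphenyl in place of 4-chlorophenyl on an aromatic nitrogen. Nothing measured in the series bears on this exchange, so no direction can be read from the data. Since compound 2 sits at the limit, the step from compound 2 to compound 3 is expected to be small, a number no higher from compound 2 to compound 3 (the limit leaves the size open), and within the usual scatter. Compound 3 is therefore expected to give about 50000 nM, with a range from 15000 nM to 150000 nM, and a fair chance that this assay again reports only a limit.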

Compound 3, half-maximal inhibitory concentration: > 50000 nM
Compound 3 gave a limit, no number (the forecaster's own chance of this, stated with the estimate: 60%); the middle value sits exactly at the limit.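

In this assay compound 3 gives > 50000 nM, a limit of the assay and not a number. Compound 2 also stands at a limit, so no step between compound 2 and compound 3 can be read: the limit of > 50000 nM in this assay, at which 2 of the 3 values shown sit.

The compounds shown leave open how 3,5-dimethylphenyl and 4-chlorophenyl on the aromatic nitrogen compare in this assay.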